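The source may report more compounds than this note shows. Statements on the series, on what has been measured and on what is new or still open speak of the compounds shown alone.

Measured so far:
- compound 1 `Cc1ccc(CC(CN/C(S)=N/Cc2ccc(NS(C)(=O)=O)cc2)COC(=O)C(C)(C)C)cc1C` — 29.3 nM
- compound 2 `Cc1ccc(CC(CN/C(S)=N/Cc2ccc(NS(C)(=O)=O)cc2)COC(=O)c2ccccc2)cc1C` — 410 nM

These are measured in an assay on isolated protein for binding affinity to transient receptor potential cation channel subfamily V member 1 (Rattus norvegicus); on this read-out higher numbers stand for weaker inhibition and lower numbers for stronger inhibition. Within the data shown here, compound 2 gives the higher of the two numbers, its only neighbour being compound 1, and the one step between them, a 14-fold higher number from compound 1 to compound 2 (1.15 log units; beyond the scatter), concerns the group on the carbonyl carbon. Compound 3 `CC(C)(C)c1ccc(CC(CN/C(S)=N/Cc2ccc(NS(C)(=O)=O)cc2)COC(=O)c2ccccc2)cc1` differs from compound 2 elsewhere: 4-(tert-butyl)phenyl in place of 3,4-dimethylphenyl on a saturated chain carbon, three bonds along the chain from an amine nitrogen and an oxygen next to a carbonyl group. Among the measured compounds shown here, no measured step bears on this change, so the expectation is a step in this assay of no set direction, and compound 3 is estimated at 400 nM, with a range from 100 nM to 1600 nM; the expected step is a 1.0-fold lower number from compound 2 to compound 3 (0.01 log units; within the scatter).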

Compound 3, inhibition constant: 239 nM
The estimate for compound 3 lay 1.7-fold (0.22 log units) above the measured number; the measured number falls inside the stated range.
By their numbers in this assay, from the lowest: compound 1; then compounds 3 and 2 (each within the scatter of the next).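

In this assay, replacing 3,4-dimethylbenzyl with 4-(tert-butyl)benzyl gives a 1.7-fold lower number from compound 2 to compound 3 (0.23 log units; within the scatter). With phenyl on the carbonyl carbon, then, this position accepts either group with no real difference in the read-out, whereas the change on the carbonyl carbon gave a 14-fold higher number from compound 1 to compound 2 (1.15 log units; beyond the scatter). Nothing available explains this result.

Going by these compounds, it remains open whether 4-(tert-butyl)phenyl would read the same with tert-butyl on the carbonyl carbon. Also open, on these data alone, is how an unsubstituted benzyl or a cyclohexylmethyl group would fare at this position.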